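Swapping 4-fluorobenzyl for 2-fluorobenzyl in a cytotoxic series

A few compounds are considered here, and "the series" means these few. Any claim that something is new, unique, unknown or untested is made for them only; others in the source may bear on it.

Among the measured compounds shown here, in a functional assay on MCF7 cells (Homo sapiens) for cytotoxicity, read by MTT assay, with a stated time of 24 h (on this read-out higher numbers stand for weaker inhibition and lower numbers for stronger inhibition), compound 1 `O=C1/C(=C/c2ccccc2F)CN(Cc2cn(Cc3ccccc3F)nn2)C/C1=C\c1ccccc1F` gives 6000 nM and compound 2 `Cc1ccc(/C=C2\CN(Cc3cn(Cc4ccc(F)cc4)nn3)C/C(=C\c3ccc(C)cc3)C2=O)cc1` gives 29000 nM as the only two numbers so far. Compound 2 therefore holds the higher of the two numbers, meaning the weaker inhibition, and its gap to compound 1 lies beyond the usual scatter. Compound 3 `Cc1ccc(/C=C2\CN(C(=S)SCc3cn(Cc4ccccc4F)nn3)C/C(=C\c3ccc(C)cc3)C2=O)cc1` returns > 100000 nM and this is a limit, not a number.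

Compound 4 `Cc1ccc(/C=C2\CN(Cc3cn(Cc4ccccc4F)nn3)C/C(=C\c3ccc(C)cc3)C2=O)cc1` is still unmeasured. It differs from compound 2 in one place, with 2-fluorophenyl in place of 4-fluorophenyl on a saturated chain carbon bound to an aromatic nitrogen and the same difference reads 4-fluorobenzyl to 2-fluorobenzyl. For the measured compounds named here, no measured pair isolates this change in this assay so any expectation rests on indirect evidence. Compound 1 at 6000 nM carries the 2-fluorobenzyl group but also differs from compound 2 elsewhere, which makes it only a weak hint towards a lower number. Compound 3 carries that group too, differs elsewhere as well and gives no number. The estimated step of a 1.6-fold lower number from compound 2 to compound 4 (0.21 log units; within the scatter) is expected to be small, leaning towards stronger inhibition and staying within the scatter. For compound 4 the expected value is 18000 nM with an estimated range from 6000 nM to 50000 nM in this measurement.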

Compound 4, half-maximal inhibitory concentration: 28700 nM
Estimate against measurement, compound 4: 1.6-fold (0.20 log units) below, within the range that was stated.
By their numbers in this assay, from the lowest: compound 1; then compounds 4 and 2 (each within the scatter of the next). At a limit, above all of these: compound 3.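

In this assay, among the compounds shown here, the exchange of 4-fluorobenzyl for 2-fluorobenzyl, on a saturated chain carbon bound to an aromatic nitrogen, gives the first reading of this position with everything else held constant: a 1.0-fold lower number from compound 2 to compound 4 (0.00 log units; within the scatter). For the compounds shown here, the change from 4-fluorophenyl to 2-fluorophenyl therefore leaves the number unmoved, and the hint drawn from compound 1 finds no support in this pair. Only compound 3 stands at a limit and not at a number, so this step rests on two true numbers: the limit of > 100000 nM in this assay, at which 1 of the 4 values shown sits.

What the compounds shown leave open is whether this position is insensitive to its substituent more broadly, since both groups compared carry a single fluorine on the same phenyl and nothing here shows how a plain benzyl, a 4-methoxybenzyl, a carboxylic acid or an amine at this place would read. Going by these compounds alone, it also remains open whether the same exchange would read the same way on the core of compound 1 or of compound 3, as no pair isolates it there.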